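The compounds below may be only part of what the source reports. "The series", "measured", "known", "first", "only" and "open" are said of these compounds alone.

Of the compounds shown here, three have been measured. Compound 1 `Cc1cc(C)cc(-c2cncc(-c3nc4cc(C(F)(F)F)ccc4[nH]3)c2N2CCC(N)CC2)c1` gives 0.014 nM in a functional assay on CHO-K1 cells for agonist activity at somatostatin receptor type 2 (Homo sapiens), read by cAMP accumulation, with a stated time of 30 min; a higher number here means that more compound is needed for the effect, a lower number that less compound is needed. Compound 3 `Cc1cc(C)cc(C(=O)Nc2cncc(-c3cc(C)cc(C)c3)c2N2CCC(N)CC2)c1` gives 0.04 nM in this assay, and compound 2 `Cc1nc(C(=O)Nc2cncc(-c3cc(Cl)cc(Cl)c3)c2N2CCC(N)CC2)c(C)o1` gives 0.47 nM. Compound 1 thus has the lowest number of the three: its gap to compound 3 lies beyond the usual scatter of repeated measurements, and its gap to compound 2 is wider still. Compound 4 `Cc1cc(C)cc(-c2cncc(-c3nc4cc(Cl)ccc4[nH]3)c2N2CCC(N)CC2)c1` has not yet been measured. It differs from compound 1 in one place: chloro in place of trifluoromethyl on an aromatic carbon. Within the data shown here, no measured pair shows this particular change, so the step is expected to be small, with no clear direction beyond the scatter. The estimate for compound 4 in this assay is 0.02 nM, between 0.007 nM and 0.06 nM. The expected step of a 1.4-fold higher number from compound 1 to compound 4 (0.15 log units; within the scatter) is accordingly slight.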

Compound 4, half-maximal effective concentration: 0.015 nM
Estimate against measurement, compound 4: 1.3-fold (0.12 log units) above, and the stated range covers the measured number.
By their numbers in this assay, from the lowest: compounds 1 and 4 (each within the scatter of the next); then compound 3; then compound 2.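

Among these compounds, replacing trifluoromethyl with chloro on this aromatic carbon gives a 1.1-fold higher number from compound 1 to compound 4 (0.03 log units; within the scatter) in this assay and provides the first comparison of compounds differing in one place. At this position, the two groups cannot be told apart in this assay, even though 4 heavy atoms are replaced by 1 heavy atom. Nothing available explains this similarity.

On these data alone, whether this tolerance extends to other groups remains open. An amine or a carboxylic acid at this position could keep the number equally low or raise it.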